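Nitrofuran chalcones: working notes on compound 3

The source may hold more compounds than are shown below. What is called first, only, known or untested is meant among the compounds shown, and "the series" means these compounds.

Within the data shown here, compound 1 `O=C(/C=C/c1ccc([N+](=O)[O-])o1)c1ccc(I)cc1` is the higher of the two numbers measured so far. In an ADME assay on THP-1 cells (Homo sapiens) for cytotoxicity, read by resazurin assay, with a stated time of 72 h (on this read-out lower numbers stand for higher toxicity in this test and higher numbers for lower toxicity in this test), compound 1 gives 49500 nM. Among the measured compounds shown here, the only other measured member, compound 2 `O=C(/C=C/c1ccc([N+](=O)[O-])o1)c1cccc(Br)c1`, carries a bromo group on the same aryl ring in a different place, and in this assay compound 2 gives 14900 nM, a lower number than compound 1 and one that lies beyond the usual scatter. For the measured compounds named here, no pair of measured compounds differs in just one place, so no single-point step is available as a yardstick.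

Compound 3 `CCCCc1ccc(C(=O)/C=C/c2ccc([N+](=O)[O-])o2)cc1` is derived from compound 1 by a single substitution: butyl in place of iodo on an aromatic carbon, on an aromatic carbon of a six-membered aromatic ring of carbon only, para to a large group. With nothing in the measured set that isolates this kind of exchange, the step of a 1.7-fold lower number from compound 1 to compound 3 (0.22 log units; within the scatter) is expected to be modest, most likely toward a somewhat lower number, but not clearly beyond the scatter. For compound 3 the estimate in this assay is 30000 nM, with a range from 10000 nM to 90000 nM.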

Compound 3, half-maximal cytotoxic concentration: 48700 nM
Compound 3: the middle estimate sits 1.6-fold (0.21 log units) below what was measured; measured number inside the range.
By their numbers in this assay, from the lowest: compound 2; then compounds 3 and 1 (each within the scatter of the next).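

Among these compounds, this is the first step between two compounds that differ in one place, and in this assay the exchange reads as a 1.0-fold lower number from compound 1 to compound 3 (0.01 log units; within the scatter). On an aromatic carbon, para to a large group, butyl with its 4 heavy atoms and iodo with its 1 heavy atom therefore cannot be told apart on this read-out, so the size of the group entering here does not separate these two compounds, at least for this one pair. Nothing at hand gives a reason for this result.

The compounds shown leave open whether this tolerance extends beyond these two groups, for instance to an amine, a carboxylic acid or a longer chain in the same place, where a group carrying hydrogen-bond donors or acceptors or a net charge would be a different kind of exchange from this one. They also leave open whether butyl in place of iodo would read the same way on another carbon of the ring, since this single step speaks only for the place it was taken at.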